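Adding fluoro to compound 3 in a cell assay

The source may report more compounds than this note shows. Statements on the series, on what has been measured and on what is new or still open speak of the compounds shown alone.

In a functional assay on MCF7 cells (Homo sapiens) for cytotoxicity, read by MTT assay, with a stated time of 24 h (a lower number here means a stronger inhibitor, a higher number a weaker inhibitor), compound 3 `Nc1cccn2cc(Cc3ccccc3)c(=O)nc12` gives 105000 nM. Compound 1 `O=c1nc2ccc(Br)cn2cc1Cc1ccc(Br)cc1` gives 97200 nM, which lies within the scatter of compound 3, although the two differ in more than one place. Compound 2 `COc1ccc(Cc2cn3cc(Br)ccc3nc2=O)cc1` reads > 1000000 nM, and this is a limit of the assay, not a number.

The next structure is compound 4 `Nc1cccn2cc(Cc3ccc(F)cc3)c(=O)nc12`. Its change is fluoro in place of hydrogen on an aromatic carbon, which means fluoro in place of hydrogen on an aromatic carbon, para to a large group. Within the data shown here, only one measured step bears on this kind of change: an at least 10-fold higher number from compound 1 to compound 2 (1.01 log units; beyond the scatter), a large step with methoxy in place of bromo on an aromatic carbon. Among the measured compounds shown here, no measured step involves fluoro, so that large size cannot simply be carried over, but it does argue for caution.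

The estimated step, a 1.1-fold lower number from compound 3 to compound 4 (0.02 log units; within the scatter), is expected to stay within the scatter, with no clear direction. For compound 4 the estimate is 100000 nM, with an expected range from 40000 nM to 300000 nM.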

Compound 4, half-maximal inhibitory concentration: 135000 nM
Compound 4: the middle estimate sits 1.4-fold (0.13 log units) below what was measured, and the stated range covers the measured number.
By their numbers in this assay, from the lowest: compounds 1, 3 and 4 (each within the scatter of the next). At a limit, above all of these: compound 2.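

In this assay, the step with fluoro in place of hydrogen on an aromatic carbon, para to a large group, is a 1.3-fold higher number from compound 3 to compound 4 (0.11 log units; within the scatter) and so stays within the scatter. Among these compounds, the only earlier step on such a ring was an at least 10-fold higher number from compound 1 to compound 2 (1.01 log units; beyond the scatter) and it swapped methoxy for bromo, whereas this step shows that a single fluoro at this carbon leaves the number where it was. Compound 2 stands at a limit of the assay, and it is the only compound shown that does: the limit of > 1000000 nM in this assay, at which 1 of the 4 values shown sits.

The compounds shown leave open whether a different group at this carbon, such as an amine or a carboxylic acid, would move the number beyond the scatter. They also leave open whether fluoro would behave the same way on the core of compound 1.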